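The source may hold more compounds than are shown below. What is called first, only, known or untested is meant among the compounds shown, and "the series" means these compounds.

In a functional assay on T98G cells (Homo sapiens) for cytotoxicity, read by MTT assay, with a stated time of 48 h (on this read-out higher numbers stand for weaker inhibition and lower numbers for stronger inhibition), compound 3 (`CC(=NNC(=S)Nc1ccccc1[N+](=O)[O-])c1ccccn1`) gives 6.6 nM, the second highest of the three numbers. Compound 1 (`CC(=NNC(=S)Nc1ccccc1F)c1ccccn1`) gives 3.1 nM, and compound 2 (`CC(=NNC(=S)Nc1cccc(I)c1)c1ccccn1`) gives 61 nM. Compound 4 (`CC(=NNC(=S)Nc1ccccc1)c1ccccn1`) has not yet been measured. It differs from compound 3 by hydrogen in place of nitro on an aromatic carbon, ortho to a large group (hydrogen in place of nitro on an aromatic carbon).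

Among the compounds with values here, one measured step bears on this change: a 2.1-fold higher number from compound 1 to compound 3 (0.33 log units; beyond the scatter), with nitro in place of fluoro on an aromatic carbon. That step is modest but beyond the scatter. Within the data shown here, no measured compound shows the removal of nitro directly, so the data fix neither the size nor the direction of this step. A modest step in this assay is therefore expected, leaning slightly towards a higher number. The expected step is a 1.5-fold higher number from compound 3 to compound 4 (0.18 log units; within the scatter). The range is kept wider on the high side, since compound 2 at 61 nM shows that much higher numbers occur among these compounds. For compound 4 the estimated value is 10 nM, with an expected range of 3 nM to 40 nM.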

Compound 4, half-maximal inhibitory concentration: 6.8 nM
Beside the measured number, compound 4's estimate is 1.5-fold (0.17 log units) above it, within the range that was stated.
By their numbers in this assay, from the lowest: compound 1; then compounds 3 and 4 (each within the scatter of the next); then compound 2.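

In this assay, within the data shown here, the first direct reading of hydrogen in place of nitro on this aromatic carbon, ortho to a large group, is a 1.0-fold higher number from compound 3 to compound 4 (0.01 log units; within the scatter). At this position, then, the nitro group of compound 3 and the hydrogen of compound 4 cannot be told apart, and the nitro group is not needed for a number in this low range. Compound 4 also gives the other two compounds a hydrogen comparator: hydrogen in place of fluoro is a 2.2-fold higher number from compound 1 to compound 4 (0.34 log units; beyond the scatter), a modest step beyond the scatter, and hydrogen in place of iodo is a 9.0-fold lower number from compound 2 to compound 4 (0.95 log units; beyond the scatter), also beyond the scatter, so among these compounds a change from hydrogen is not always silent.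

The compounds shown leave open whether an amine, a methoxy group or a carboxylic acid on this aromatic carbon would stay level with hydrogen and nitro, or would shift the number as fluoro and iodo do. Nothing measured here speaks to what lies behind the size of any of these steps.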